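Swapping the thioether aryl group on a cinnamamide scaffold

The compounds below may be only part of what the source reports. "The series", "measured", "known", "first", "only" and "open" are said of these compounds alone.

Compound 1 `COc1ccc(SCc2ccc(/C=C/C(=O)Nc3ccccc3N)cc2)cc1OC` gives 46% in a functional assay on A-375 cells (Homo sapiens) for inhibition, read by CCK-8 assay, with a stated time of 72 h, tested at 2 uM (a higher number here means more inhibition of growth at the concentration tested, a lower number less inhibition of growth), and stands highest of the two compounds measured. Compound 2 `COc1ccc(SCc2ccc(C(=O)Nc3ccccc3N)cc2)cc1OC` gives 18.1% in this assay, a value that lies beyond the scatter below that of compound 1. Compound 3 `CC(C)(C)c1ccc(SCc2ccc(/C=C/C(=O)Nc3ccccc3N)cc2)cc1` is not yet measured and differs from compound 1 in a single place: 4-(tert-butyl)phenyl in place of 3,4-dimethoxyphenyl on a sulfur. Within the data shown here, no measured pair shows this exchange, so no step in this assay is known for it. Compound 3 is expected to remain roughly at the level already seen, with an estimated step of a number 6 percentage points lower from compound 1 to compound 3 (within the scatter). For compound 3 the estimated value is 40%, with a range from 15% to 65%.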

Compound 3, percent growth inhibition at one concentration: 38.4%
Estimate against measurement, compound 3: 1.6 percentage points above; the range from low to high includes it.
By their numbers in this assay, from the lowest: compound 2; then compounds 3 and 1 (each within the scatter of the next).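

In this assay the exchange on the sulfur gives a number 7.6 percentage points lower from compound 1 to compound 3 (within the scatter) and so shows that this position tolerates 4-(tert-butyl)phenyl in place of 3,4-dimethoxyphenyl. The 2 hydrogen-bond acceptors counted on the leaving group are therefore not required to keep growth inhibition at the level of compound 1. Nothing measured on these compounds offers an explanation for this result. On these data alone, whether an aryl group carrying an amine or a carboxylic acid would hold this level on the sulfur remains open. So does whether the same exchange would read alike on the core of compound 2.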